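The compounds below may be only part of what the source reports. "The series", "measured", "known", "first", "only" and "open" are said of these compounds alone.

Measured so far in a functional assay on KG-1 cells (Homo sapiens) for cytotoxicity, read by luminescence and CellTiter-Glo, with a stated time of 3 days; a lower number here means a stronger inhibitor, a higher number a weaker inhibitor:
- compound 1, `N#Cc1ccc(NC(=O)c2cc(F)ccc2O)cc1`: 2670 nM
- compound 2, `N#Cc1ccc(NC(=O)c2ccc(C(F)(F)F)cc2O)cc1`: 1440 nM
- compound 3, `COc1cccc(C(=O)Nc2ccc(C#N)cc2)c1O`: > 10000 nM

Compound 3 stands apart from the other two. In this assay, within the data shown here, compound 3 gives only the assay limit, > 10000 nM, not a number, so its true potency is unknown beyond that limit; it is the one of the three values that sits at the limit of > 10000 nM in this assay, at which 1 of the 3 values shown sits. Compound 1 and compound 2, whose half-maximal inhibitory concentrations lie within the usual scatter of each other, both give measured numbers.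

The next compound, compound 4, `N#Cc1ccc(NC(=O)c2ccccc2O)cc1`, is reached from compound 3 by a single change: hydrogen in place of methoxy on an aromatic carbon. Among the measured compounds shown here, no measured pair of compounds differing in one place exists here, so the size of this step can only be anticipated. Compound 4 carries the same hydroxy group and the same nitrile-bearing anilide as compound 1 and compound 2, both of which give numbers in this assay, so compound 4 is expected to give a number as well. Compound 4 is estimated at 4000 nM, within 1500 nM to 12000 nM, which is expected to correspond to a step of an at least 2.5-fold lower number from compound 3 to compound 4 (0.39 log units; beyond the scatter) toward stronger inhibition.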

Compound 4, half-maximal inhibitory concentration: 5370 nM
For compound 4 the middle estimate is 1.3-fold (0.13 log units) below the measured one; the range from low to high includes it.
By their numbers in this assay, from the lowest: compounds 2, 1 and 4 (each within the scatter of the next, the first and the last beyond it). At a limit, above all of these: compound 3.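

In this assay the change to hydrogen in place of methoxy can be read only as a floor (an at least 1.8-fold lower number from compound 3 to compound 4 (0.27 log units; that floor lies within the scatter)). On these data alone, compound 3 gives a limit and not a number, so the true size of this change stays unknown: the limit of > 10000 nM in this assay, at which 1 of the 4 values shown sits. Hydrogen in place of trifluoromethyl gives a step beyond the scatter (a 3.7-fold higher number from compound 2 to compound 4 (0.57 log units; beyond the scatter)), whereas the step for hydrogen in place of fluoro stays within it (a 2.0-fold higher number from compound 1 to compound 4 (0.30 log units; within the scatter)), so of these two only the trifluoromethyl change is clearly separated from hydrogen.

As far as these compounds go, how far methoxy truly lies from hydrogen remains open. So does whether an amine, a carboxylic acid or a longer alkoxy chain on that same aromatic carbon would give a measured number in this assay (5370 nM for compound 4 being the reference).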